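A few compounds are considered here, and "the series" means these few. Any claim that something is new, unique, unknown or untested is made for them only; others in the source may bear on it.

Compound 2, with the structure `Nc1scc(CN2CCN(c3cccc(Cl)c3)CC2)c1C(=O)c1ccc(Cl)cc1`, stands lowest of the two numbers obtained in a functional assay on CHO cells with adenosine receptor A1 (Homo sapiens) as the target, read by cAMP accumulation and immunoassay, with a stated time of 6 min, tested at 0.1 uM; a lower number here means a stronger effect, a higher number a weaker effect of the compound at the concentration tested; in this assay compound 2 gives -20%. Its nearest neighbour is compound 1, built as `Nc1scc(CN2CCN(c3ccc(Cl)cc3F)CC2)c1C(=O)c1ccc(Cl)cc1`, which in this assay gives -9.4%. Going by the values given here, the single measured step, a number 10.6 percentage points lower from compound 1 to compound 2 (beyond the scatter), arose from the exchange of 3-chlorophenyl in place of 4-chloro-2-fluorophenyl on an amine nitrogen in a ring.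

Compound 3, drawn as `Nc1scc(CN2CCN(c3cc(Cl)ccc3Cl)CC2)c1C(=O)c1ccc(Cl)cc1`, has not yet been tested. It differs from compound 2 by chloro in place of hydrogen on an aromatic carbon, namely on an aromatic carbon of a six-membered aromatic ring of carbon only, ortho to a large group and para to a chloro group, so that 3-chlorophenyl becomes 2,5-dichlorophenyl. The step from compound 1 to compound 2 bears on this only loosely, since it too altered the substitution of the same aryl ring, and it was modest in size. Among the compounds with values here, no measured pair shows the addition of a chloro by itself. The expected outcome for compound 3 is therefore a step of about a number 6 percentage points higher from compound 2 to compound 3 (within the scatter), essentially none beyond the scatter, with a slight lean toward a higher number. Compound 3 is thus estimated at -14%, within a range from -30% to 2%.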

Compound 3, a percentage reported as activity, at one concentration (the size of the read-out at that concentration, not a potency): -6.2%
The estimate for compound 3 lay 7.8 percentage points below the measured number; low and high end bracket the measured number.
By their numbers in this assay, from the lowest: compound 2; then compounds 1 and 3 (each within the scatter of the next).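

In this assay, the addition of chloro on an aromatic carbon, ortho to a large group and para to a chloro group, gave a number 13.8 percentage points higher from compound 2 to compound 3 (beyond the scatter), which shows that this one place on the aryl ring responds to a single added heavy atom, and that here the response runs toward a weaker effect at the concentration tested. The earlier step had changed the ring's substitution at more than one place, whereas this pair isolates one position, and the outcome also shows that 2,5-dichlorophenyl and 4-chloro-2-fluorophenyl cannot be told apart, with a number 3.2 percentage points higher from compound 1 to compound 3 (within the scatter). Nothing at hand explains why the added chloro moves the number in this direction.

Open still is whether the shift belongs to chloro itself or to any group on that carbon, since fluoro, methyl or methoxy in the same place would separate those two readings. On these data alone, it also remains open whether chloro on that carbon has the same effect when the 3-chloro substituent is absent, or when the piperazine-bearing aryl ring is replaced by an unsubstituted phenyl or a pyridine.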